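Adding a group to the ring nitrogen of compound 1

This account rests on a few compounds, and the source may have more. Where it says the series, first, only, none or still open, it means among the compounds named here.

Measured in a functional assay on HepG2 cells (Homo sapiens) for cytotoxicity, read by MTT assay, with a stated time of 72 h; on this read-out higher numbers stand for weaker inhibition and lower numbers for stronger inhibition:
Compound 1 `CNC(=O)c1cc(Oc2ccc(C3=NNC(c4cccc([N+](=O)[O-])c4)C3)cc2)ccn1`: 26500 nM
Compound 2 `CNC(=O)c1cc(Oc2ccc(C3=NNC(c4ccccc4)C3)cc2)ccn1`: 1500 nM

Compound 1 holds the higher of the two numbers in this assay. Compound 3 `CNC(=O)c1cc(Oc2ccc(C3=NN(C(N)=S)C(c4cccc([N+](=O)[O-])c4)C3)cc2)ccn1` differs from it by one change: a group of 3 heavy atoms (1 carbon, 1 nitrogen, 1 sulfur; no ring) in place of a hydrogen atom, on an amine nitrogen in a ring. Going by the values given here, the only measured step, an 18-fold lower number from compound 1 to compound 2 (1.25 log units; beyond the scatter), replaces the nitro group and leaves this nitrogen untouched. It shows that numbers in this small set can move widely, but it gives no direction for the new group. A moderate move to a lower number is therefore expected, with wide uncertainty. The estimated step is a 2.7-fold lower number from compound 1 to compound 3 (0.42 log units; beyond the scatter). For compound 3 the expected value is 10000 nM, with an estimated range of 2500 nM to 40000 nM.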

Compound 3, half-maximal inhibitory concentration: > 50000 nM
Compound 3: only a limit was reported (the forecaster's own chance of this, stated with the estimate: 10%); at least 5.0-fold (0.69 log units) between middle value and limit.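

In this assay, the group of 3 heavy atoms on the amine nitrogen in a ring gives an at least 1.8-fold higher number from compound 1 to compound 3 (0.27 log units; that floor lies within the scatter). Going by these compounds alone, this is the first reading at this nitrogen, and it shows that this change brings no lower number to compound 1, though how far the number rises cannot be told. The reading for compound 3 is a limit and not a number: the limit of > 50000 nM in this assay, at which 1 of the 3 values shown sits.

Going by these compounds, it remains open whether an acetyl or a methyl group on this nitrogen would lower the number. On these data alone, it is also open whether the same group would act alike on compound 2, which carries hydrogen in place of nitro.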